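The source may report more compounds than this note shows. Statements on the series, on what has been measured and on what is new or still open speak of the compounds shown alone.

Compound 3 `Cn1cc(SCc2nnc(SCc3ccc(Cl)cc3Cl)n2-c2c(Cl)cccc2Cl)c2ccccc21` gives only a limit in a toxicity assay on HEK-293T cells (Homo sapiens) for cytotoxicity, read by CCK-8 assay, with a stated time of 48 h (on this read-out higher numbers stand for lower toxicity in this test and lower numbers for higher toxicity in this test), namely > 100000 nM. Compound 1 `Cn1cc(SCc2nnc(S)n2-c2c(Cl)cccc2Cl)c2ccccc21` likewise gives only a limit, > 100000 nM. Compound 2 `Cn1cc(SCc2nnc(SCc3cc(C(F)(F)F)ccc3Cl)n2-c2c(Cl)cccc2Cl)c2ccccc21` gives a number in this assay, 53800 nM. Two of the three values therefore sit at the same limit (the limit of > 100000 nM in this assay, at which 2 of the 3 values shown sit). Compound 4 `Cn1cc(SCc2nnc(SCc3cc(Cl)ccc3Cl)n2-c2c(Cl)cccc2Cl)c2ccccc21` differs from compound 3 by 2,5-dichlorophenyl in place of 2,4-dichlorophenyl on a saturated chain carbon bound to a sulfur. The measured steps that bear on this change are an at least 1.8-fold higher number from compound 2 to compound 3 (0.26 log units; that floor lies within the scatter), a step that the two limits leave unreadable from compound 1 to compound 3 and an at least 1.8-fold lower number from compound 1 to compound 2 (0.26 log units; that floor lies within the scatter); none of them is readable as a step beyond the scatter, so no change beyond the scatter is expected in this assay. Compound 4 is estimated at 100000 nM, with a range from 45000 nM to 250000 nM. This estimate means a number no higher from compound 3 to compound 4 (the limit leaves the size open), expected to stay within the scatter.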

Compound 4, half-maximal cytotoxic concentration: > 100000 nM
Compound 4 was reported as a limit; the forecaster's own chance of this, stated with the estimate: 60%; the middle value lies on the limit itself.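

In this assay compound 4 gives > 100000 nM, which is a limit and not a number. Chloro in place of trifluoromethyl on an aromatic carbon gives an at least 1.8-fold higher number from compound 2 to compound 4 (0.26 log units; that floor lies within the scatter), so this comparison does not establish a real difference between the two groups. The steps to compound 4 from compound 1 and from compound 3 cannot be read, with both ends of each sitting at one limit: the limit of > 100000 nM in this assay, at which 3 of the 4 values shown sit.

Still open, going by these compounds, is how far compounds 1, 3 and 4 lie past that limit. Also open, on these data alone, is whether a benzyl carrying an amine or a carboxylic acid would give a number in this assay.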